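A few compounds are considered here, and "the series" means these few. Any claim that something is new, unique, unknown or untested is made for them only; others in the source may bear on it.

Working notes on the series, read in a functional assay on CCRF-CEM cells (Homo sapiens); on this read-out higher numbers stand for weaker inhibition and lower numbers for stronger inhibition. Compound 1 `CN(C)CC1CCC/C(=C\c2ccc(OC(=O)/C=C/c3ccc(Br)cc3)cc2)C1=O` gives 4440 nM. Compound 2 `O=C1CCCC/C1=C\c1ccc(OC(=O)c2ccc(Cl)cc2)cc1` gives 41000 nM, the higher of the two numbers, and its gap to compound 1 lies beyond the scatter. These two compounds differ in more than one place, so the gap cannot be assigned to a single change.

Compound 3 `Cc1ccc(C(=O)Oc2ccc(/C=C3\CCCCC3=O)cc2)cc1` is not yet measured. It differs from compound 2 at one point: methyl in place of chloro on an aromatic carbon. Going by the values given here, no measured pair shows this change or any other single change, so the expectation starts from compound 2 at 41000 nM. The expected 1.2-fold lower number from compound 2 to compound 3 (0.07 log units; within the scatter) stays within the scatter in this assay, with no firm direction. The estimate for compound 3 is 35000 nM, with an expected range of 14000 nM to 90000 nM.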

Compound 3, half-maximal inhibitory concentration: 22700 nM
The estimate for compound 3 lay 1.5-fold (0.19 log units) above the measured number; measured number inside the range.
By their numbers in this assay, from the lowest: compound 1; then compounds 3 and 2 (each within the scatter of the next).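

Going by these compounds alone, the first single change gives a 1.8-fold lower number from compound 2 to compound 3 (0.26 log units; within the scatter) in this assay, so 4-chlorophenyl and 4-methylphenyl cannot be told apart on this pair. At this position on an aromatic carbon, para to a large group, methyl in place of chloro exchanges one heavy atom for one, with no ring, hydrogen-bond donor, hydrogen-bond acceptor or net charge entering or leaving, and the number moves no further than the scatter. Nothing measured here bears on a cause for this result.

As far as these compounds go, whether the same position would accept a group of another kind, such as an amine, a carboxylic acid or a longer chain, remains open. Compound 1 differs from compound 2 and compound 3 in more than one place, so its gaps to them cannot be read as the effect of any single change.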